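Cyclopropyl to tert-butyl on the chain next to the core

The source may report more compounds than this note shows. Statements on the series, on what has been measured and on what is new or still open speak of the compounds shown alone.

Among the compounds with values here, compound 2 `NC(=O)COc1ccc2c(c1)S(=O)(=O)N=C(c1c(O)c(-c3cccs3)nn(CCC3CC3)c1=O)N2` gives 0.2 h in an in vitro ADME assay on microsomes from liver (Homo sapiens) for metabolic stability (a higher number here means that the compound lasts longer, a lower number that the compound disappears faster), the lower of the two numbers so far, though still within the scatter of compound 1 `CC(C)CCn1nc(-c2cccs2)c(O)c(C2=NS(=O)(=O)c3cc(OCC(N)=O)ccc3N2)c1=O`, which gives 0.383 h. Compound 3 `CC(C)(C)CCn1nc(-c2cccs2)c(O)c(C2=NS(=O)(=O)c3cc(OCC(N)=O)ccc3N2)c1=O` differs from compound 2 by tert-butyl in place of cyclopropyl on a saturated chain carbon, two bonds along the chain from an aromatic nitrogen. Within the data shown here, the one measured step that bears on this, exchanging one small alkyl for another at the same place, was a 1.9-fold lower number from compound 1 to compound 2 (0.28 log units; within the scatter). A third small alkyl there is therefore expected to shift this assay by no more than the scatter. Compound 3 is estimated at 0.3 h (range 0.12 h to 0.75 h), a step of a 1.5-fold higher number from compound 2 to compound 3 (0.18 log units; within the scatter) that is expected to stay within the scatter.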

Compound 3, half-life: 0.35 h
Compound 3: the middle estimate sits 1.2-fold (0.07 log units) below what was measured; measured number inside the range.
By their numbers in this assay, from the lowest: compounds 2, 3 and 1 (each within the scatter of the next).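

Tert-butyl in place of cyclopropyl gives a 1.8-fold higher number from compound 2 to compound 3 (0.24 log units; within the scatter) in this assay and methyl in place of hydrogen on a saturated chain carbon bound to three saturated chain carbons gives a 1.1-fold lower number from compound 1 to compound 3 (0.04 log units; within the scatter) in the same read-out. At this position, then, neither the ring of compound 2 nor the added methyl of compound 3 separates the compounds, and all three alkyl ends lie within the scatter of one another. Nothing measured here gives a reason for this. From the compounds shown here alone, whether an amine or a carboxylic acid on this chain, or a longer chain, would move this assay beyond the scatter stays open.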